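The compounds below may be only part of what the source reports. "The series", "measured", "known", "first", "only" and "open" are said of these compounds alone.

Measured in a functional assay on HeLa cells (Homo sapiens) for inhibition, read by MTT assay, with a stated time of 72 h; a lower number here means a stronger inhibitor, a higher number a weaker inhibitor:
- compound 1 `CNC(=O)CCCCCCCn1nc(-c2ccc3oc(N)nc3c2)c2c(N)ncnc21` gives 12900 nM
- compound 2 `Nc1ncnc2c1c(-c1cnc3[nH]ccc3c1)nn2CCCCCCCCCC(=O)NO` gives 7560 nM
- compound 3 `Nc1ncnc2c1c(-c1cnc3[nH]ccc3c1)nn2CCCCCCCCC(=O)NO` gives 7470 nM

Compound 1 has the highest number of the three, but its gaps to compound 2 and compound 3 are both within the scatter, so no ordering can be read from them. The one shown step, a 1.0-fold lower number from compound 2 to compound 3 (0.01 log units; within the scatter), changes the chain by one carbon and leaves the number unchanged.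

Compound 4 `Nc1nc2cc(-c3nn(CC(=O)NO)c4ncnc(N)c34)ccc2o1` differs from compound 1 by hydroxycarbamoyl in place of 6-(methylcarbamoyl)hexyl on a saturated chain carbon bound to an aromatic nitrogen. Within the data shown here, no measured step covers this change: the chain is lost almost entirely and the amide end becomes the hydroxycarbamoyl found in compound 2 and compound 3. Among the measured compounds shown here, the only guidance is that all three numbers sit close together, so compound 4 is expected near that level, with wide uncertainty, a step of a 1.3-fold lower number from compound 1 to compound 4 (0.11 log units; within the scatter). Compound 4 is estimated at 10000 nM, range 3000 nM to 40000 nM.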

Compound 4, half-maximal inhibitory concentration: > 150000 nM
Compound 4 was reported as a limit (the forecaster's own chance of this, stated with the estimate: 15%); middle value at least 15-fold (1.17 log units) away from the limit.
By their numbers in this assay, from the lowest: compounds 3, 2 and 1 (each within the scatter of the next). At a limit, above all of these: compound 4.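

In this assay, among these compounds, hydroxycarbamoyl in place of 6-(methylcarbamoyl)hexyl on a saturated chain carbon bound to an aromatic nitrogen gives an at least 11-fold higher number from compound 1 to compound 4 (1.06 log units; beyond the scatter), the only step beyond the scatter. The earlier change at the chain, a 1.0-fold lower number from compound 2 to compound 3 (0.01 log units; within the scatter), gave no sign that this place could respond so strongly. The value of compound 4 is a limit, not a number: the limit of > 150000 nM in this assay, at which 1 of the 4 values shown sits.

This change alters chain length and chain end together, so their contributions remain unseparated. As far as these compounds go, on the core of compound 1, a longer chain ending in hydroxycarbamoyl, or one ending in a carboxylic acid or an amine, remains open.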